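This account rests on a few compounds, and the source may have more. Where it says the series, first, only, none or still open, it means among the compounds named here.

Working notes on the series.

In a functional assay on MCF7 cells (Homo sapiens) for cytotoxicity, read by MTT assay, with a stated time of 72 h (on this read-out higher numbers stand for weaker inhibition and lower numbers for stronger inhibition), compound 1 `Cc1ccc(-n2nc(C(=O)Nc3ccc(Oc4ncnc5[nH]ccc45)cc3)c(C)cc2=O)cc1` gives 3620 nM and compound 3 `Cc1cc(=O)n(-c2ccc(Br)cc2F)nc1C(=O)Nc1ccc(Oc2ncnc3[nH]ccc23)cc1` gives 3210 nM; compound 2 `Cc1cc(=O)n(-c2ccccc2OC(F)(F)F)nc1C(=O)Nc1ccc(Oc2ncnc3[nH]ccc23)cc1` gives 32000 nM, the highest of the three numbers, with an 8.8-fold higher number from compound 1 to compound 2 (0.95 log units; beyond the scatter) and a 10-fold lower number from compound 2 to compound 3 (1.00 log units; beyond the scatter) setting it apart from the other two, while a 1.1-fold lower number from compound 1 to compound 3 (0.05 log units; within the scatter) leaves compounds 1 and 3 indistinguishable. All three measured steps exchange the aryl group on the aromatic nitrogen of the shared core.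

Compound 4 `Cc1cc(=O)n(-c2ccccc2OC(F)(F)F)nc1C(=O)Nc1ccc(Oc2ncnc3c2ccn3C)cc1` leaves that aryl group as in compound 2 and instead alters the other end of the molecule: methyl in place of hydrogen on an aromatic nitrogen. Among the compounds with values here, no measured step touches this position, so none of the comparisons in this assay bears on it directly; they only show how far the series moves when the aryl group changes, as in a 10-fold lower number from compound 2 to compound 3 (1.00 log units; beyond the scatter). With nothing to point either way, the expectation for this small change is a step of no size beyond the scatter, the estimated step being no change at the digits printed from compound 2 to compound 4 (within the scatter). Compound 4 is therefore expected to give about 32000 nM in this assay, with the estimate spanning 10000 nM to 100000 nM.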

Compound 4, half-maximal inhibitory concentration: 27000 nM
For compound 4 the middle estimate is 1.2-fold (0.07 log units) above the measured one; measured number inside the range.
By their numbers in this assay, from the lowest: compounds 3 and 1 (each within the scatter of the next); then compounds 4 and 2 (each within the scatter of the next).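

Methyl in place of hydrogen on an aromatic nitrogen of the five-membered ring is the first change shown at this end of the molecule, and in this assay it gives a 1.2-fold lower number from compound 2 to compound 4 (0.07 log units; within the scatter). This position therefore takes the added methyl, and the loss of the hydrogen on that nitrogen, without a step beyond the scatter, whereas exchanging the aryl group moved the number well beyond it. No measurement shown bears on why this step is so small, so it stands as an observation only.

Going by these compounds, this reading rests on a single pair carrying the 2-(trifluoromethoxy)phenyl group, so it stays open whether methyl would give an equally small step with the 4-methylphenyl group of compound 1 or the 4-bromo-2-fluorophenyl group of compound 3. On these data alone, it also stays open whether this nitrogen would tolerate more than methyl, such as a longer chain or a chain ending in an amine or a carboxylic acid.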